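One aryl group exchanged on the way to compound 4

A few compounds are considered here, and "the series" means these few. Any claim that something is new, unique, unknown or untested is made for them only; others in the source may bear on it.

- compound 1 `Cc1ccc(N(C(=O)c2cccc([N+](=O)[O-])c2)C(=S)OCCN2C(=O)c3ccccc3C2=O)cc1` gives 100000 nM
- compound 2 `Cc1ccc(C(=O)N(C(=S)OCCN2C(=O)c3ccccc3C2=O)c2ccc(C)cc2)cc1` gives 83000 nM
- compound 3 `Cc1ccc(N(C(=O)c2cc(F)cc(F)c2)C(=S)OCCN2C(=O)c3ccccc3C2=O)cc1` gives 54000 nM

These values come from an ADME assay on MT4 cells (Homo sapiens) for cytotoxicity, read by MTT assay; a higher number here means that more compound is tolerated, a lower number that less compound is tolerated. Compound 3 cannot be separated from the other two, as shown by a 1.9-fold lower number from compound 1 to compound 3 (0.27 log units; within the scatter) and a 1.5-fold lower number from compound 2 to compound 3 (0.19 log units; within the scatter). Compound 4 `Cc1ccc(N(C(=O)c2cccc(Cl)c2Cl)C(=S)OCCN2C(=O)c3ccccc3C2=O)cc1` differs from it by one exchange: 2,3-dichlorophenyl in place of 3,5-difluorophenyl on a carbonyl carbon. This places 2,3-dichlorophenyl in place of 3,5-difluorophenyl on a carbonyl carbon. For the measured compounds named here, three measured steps bear on it, all exchanges at that same place: the two above and a 1.2-fold lower number from compound 1 to compound 2 (0.08 log units; within the scatter). None leaves the scatter, so no step beyond the scatter is expected in this assay. Going by the values given here, no dichlorophenyl compound has been measured, which leaves the range wide. The estimated step is a 1.1-fold higher number from compound 3 to compound 4 (0.05 log units; within the scatter). For compound 4 the estimated value is 60000 nM, with an expected range of 25000 nM to 100000 nM.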

Compound 4, half-maximal cytotoxic concentration: 35000 nM
Beside the measured number, compound 4's estimate is 1.7-fold (0.23 log units) above it; low and high end bracket the measured number.
By their numbers in this assay, from the lowest: compounds 4, 3, 2 and 1 (each within the scatter of the next, the first and the last beyond it).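

In this assay this carbonyl position now shows exchanges that leave the scatter: 2,3-dichlorophenyl gives a 2.4-fold lower number from compound 2 to compound 4 (0.38 log units; beyond the scatter) and a 2.9-fold lower number from compound 1 to compound 4 (0.46 log units; beyond the scatter) as the two modest steps seen so far. Set against 3,5-difluorophenyl, the same group gives only a 1.5-fold lower number from compound 3 to compound 4 (0.19 log units; within the scatter) and so does not separate compound 4 from compound 3. The two halogen-bearing compounds therefore cannot be told apart, although only compound 4 separates from the 4-methylphenyl and 3-nitrophenyl compounds.

On these data alone, it remains open how an amine or a carboxylic acid on this aryl ring, or a longer chain in its place, would read here. Nothing available accounts for these steps.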